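From cyclopropylamino to diethylamino on the sulfonyl sulfur

The source may hold more compounds than are shown below. What is called first, only, known or untested is meant among the compounds shown, and "the series" means these compounds.

Compounds measured in a functional assay on MIA PaCa-2 cells (Homo sapiens) for inhibition, read by MTT assay, with a stated time of 7 days; on this read-out lower numbers stand for stronger inhibition and higher numbers for weaker inhibition:
Compound 1 `CCN(CC)S(=O)(=O)c1ccc(S(=O)(=O)N2CCC[C@@H](C(=O)N[C@@H]3CCN(C(=O)OC(C)(C)C)C3)C2)cc1`: 200 nM
Compound 2 `CCN(CC)S(=O)(=O)c1ccc(S(=O)(=O)N2CCC[C@@H](C(=O)NC3CN(C(=O)OC(C)(C)C)C3)C2)cc1`: 200 nM
Compound 3 `CC(C)c1noc(N2CCN(C(=O)[C@@H]3CCCN(S(=O)(=O)c4ccc(S(=O)(=O)NC5CC5)cc4)C3)CC2)n1`: 1000 nM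

Compound 3, at 1000 nM, has the highest number of the three and so the weakest inhibition, with a gap to each of the others that lies beyond the scatter. Compound 4 `CCN(CC)S(=O)(=O)c1ccc(S(=O)(=O)N2CCC[C@@H](C(=O)N3CCN(c4nc(C(C)C)no4)CC3)C2)cc1` departs from compound 3 at a single place: diethylamino in place of cyclopropylamino on a sulfonyl sulfur. That is, diethylamino stands in place of cyclopropylamino on a sulfonyl sulfur.

Among the compounds with values here, the one measured step, no change at the digits printed from compound 1 to compound 2 (within the scatter), concerns a change on an amide-type nitrogen and says nothing directly about the sulfonyl sulfur. Within the data shown here, no measured pair isolates the present change. Among the measured compounds shown here, the only indirect evidence is that compound 1 at 200 nM and compound 2 at 200 nM both carry diethylamino there and both have lower numbers than compound 3. However, they also differ from compound 3 on the amide side, so the gap cannot be credited to diethylamino alone. Only part of that gap is therefore expected to carry over, in the direction of stronger inhibition in this assay.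

An estimated 2.5-fold lower number from compound 3 to compound 4 (0.40 log units; beyond the scatter) is expected, though with wide uncertainty. For compound 4 the estimated value is 400 nM, with an expected range from 130 nM to 1200 nM.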

Compound 4, half-maximal inhibitory concentration: 50 nM
Compound 4: middle estimate off by 8.0-fold (0.90 log units), on the high side, and the stated range ends above it.
By their numbers in this assay, from the lowest: compound 4; then compounds 1 and 2 (each within the scatter of the next); then compound 3.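

In this assay, the replacement of cyclopropylamino by diethylamino on a sulfonyl sulfur gives a 20-fold lower number from compound 3 to compound 4 (1.30 log units; beyond the scatter), and this is the first pair shown in which the group on that sulfur is the only thing that differs. Compounds 1 and 2 could not separate this group from the amide side, whereas this pair shows that the change at this position can, by itself, shift the read-out by a large amount, with the entering group having no ring and 0 hydrogen-bond donors where the leaving group has a three-membered ring and 1 hydrogen-bond donor. No measurement shown here bears on why the step is so large.

Within the data shown here, the single pair cannot tell whether the ring, the donor or the two ethyl chains account for the step, and methylamino, dimethylamino or dipropylamino on the same sulfur would be needed to pull these apart. Among these compounds, it also remains open whether a step of this size would hold with the amide side of compound 1 or compound 2 in place of the one shared by compound 3 and compound 4.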